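Compound 2 to compound 3: amino for fluoro

The source may hold more compounds than are shown below. What is called first, only, known or untested is meant among the compounds shown, and "the series" means these compounds.

Measured in a functional assay on SW-620 cells (Homo sapiens) for cytotoxicity, read by MTT assay, with a stated time of 48 h; on this read-out lower numbers stand for stronger inhibition and higher numbers for weaker inhibition:
- Compound 1 `COc1cc(C(=O)c2cn(-c3cccc(N)c3)cc2-c2ccc(N)cc2)cc(OC)c1OC`: 28 nM
- Compound 2 `COc1cc(C(=O)c2cn(-c3ccc(F)cc3)cc2-c2ccc(N)cc2)cc(OC)c1OC`: 47 nM

Compound 2 cannot be separated from compound 1 on these numbers. Compound 3 `COc1cc(C(=O)c2cn(-c3ccc(N)cc3)cc2-c2ccc(N)cc2)cc(OC)c1OC` has not yet been measured. Its difference from compound 2 is amino in place of fluoro on an aromatic carbon, para to a large group. Within the data shown here, only one measured step bears on this, with 4-fluorophenyl in place of 3-aminophenyl: a 1.7-fold higher number from compound 1 to compound 2 (0.22 log units; within the scatter). Given that small step, no change beyond the scatter is expected in this assay. Compound 3 is estimated at 32 nM, with an expected range from 13 nM to 80 nM. This estimate means an expected 1.5-fold lower number from compound 2 to compound 3 (0.17 log units; within the scatter).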

Compound 3, half-maximal inhibitory concentration: 61 nM
The estimate for compound 3 lay 1.9-fold (0.28 log units) below the measured number; the measured number falls inside the stated range.
By their numbers in this assay, from the lowest: compounds 1, 2 and 3 (each within the scatter of the next, the first and the last beyond it).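

In this assay, amino in place of fluoro on this aromatic carbon, para to a large group, gives a 1.3-fold higher number from compound 2 to compound 3 (0.11 log units; within the scatter), so this exchange is not resolved at this position. Moving the amino group on the ring gives a 2.2-fold higher number from compound 1 to compound 3 (0.34 log units; beyond the scatter), the only modest step beyond the scatter among these compounds, so the amino group's placement registers where the exchange with fluoro does not. Nothing available explains either result. The compounds shown leave open whether a carboxylic acid or a longer chain such as aminoethyl at this place would move the number beyond the scatter.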